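The source may report more compounds than this note shows. Statements on the series, on what has been measured and on what is new or still open speak of the compounds shown alone.

Of the compounds shown here, three have been measured in a physicochemical assay for lipophilicity, measured as octanol-water partition; on this read-out lower numbers stand for lower lipophilicity and higher numbers for higher lipophilicity. Compound 1, `O=C(COc1cccc2ccccc12)N/N=C/c1cccc(O)c1`, gives 3.73. Compound 2, `COc1ccc(/C=N/NC(=O)COc2cccc3ccccc23)cc1O`, gives 3.48, and compound 3, `COc1ccc(/C=N/NC(=O)COc2cccc3ccccc23)cc1OC`, gives 3.51. Compound 1 holds the highest of the three numbers, but its gaps to compound 2 and to compound 3 both lie within the usual scatter, so no order among the three is claimed. The two measured steps are a number 0.25 log units lower from compound 1 to compound 2 (within the scatter) and a number 0.03 log units higher from compound 2 to compound 3 (within the scatter), both within the scatter.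

Compound 4, `O=C(COc1cccc2ccccc12)N/N=C/c1cccc(Br)c1`, has not yet been measured. It differs from compound 1 by bromo in place of hydroxy on an aromatic carbon. Neither measured step exchanges a hydroxy for a bromo, and neither touches the carbon in question, so neither bears directly on this change; the estimate rests on the change itself rather than on a measured precedent. For compound 4 the expected outcome in this assay is a rise beyond the scatter, a number 0.77 log units higher from compound 1 to compound 4 (beyond the scatter). The estimate for compound 4 is 4.5, with a range from 4 to 5.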

Compound 4, partition coefficient: 4.81
For compound 4 the middle estimate is 0.31 log units below the measured one; the range from low to high includes it.
By their numbers in this assay, from the lowest: compounds 2, 3 and 1 (each within the scatter of the next); then compound 4.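

In this assay, going by these compounds alone, the exchange of 3-hydroxyphenyl for 3-bromophenyl gives a number 1.08 log units higher from compound 1 to compound 4 (beyond the scatter) and is the only step so far that lies beyond the scatter. The read-out therefore responds to this change on an aromatic carbon meta to a large group, whereas a number 0.25 log units lower from compound 1 to compound 2 (within the scatter) and a number 0.03 log units higher from compound 2 to compound 3 (within the scatter) both stay within the scatter. Nothing measured here explains the size of this step or separates the loss of hydroxy from the entry of bromo.

Open, as far as these compounds go, is whether an amine, a carboxylic acid or a longer chain such as propyl on this carbon would move the read-out as far as bromo does. Also open, from the compounds shown here alone, is whether bromo in place of hydroxy would give a step of similar size on the core of compound 2.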